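A few compounds are considered here, and "the series" means these few. Any claim that something is new, unique, unknown or untested is made for them only; others in the source may bear on it.

Measured so far:
compound 1 `C/C(=N/Nc1nc(-c2ccc(F)cc2)cs1)c1ccncc1`, 40% in an in vitro assay on BTI-TN-5B1-4 cells for inhibition of Amine oxidase [flavin-containing] A (Homo sapiens), read by Amplex Red, with a stated time of 15 min, tested at 100 uM; on this read-out higher numbers stand for more inhibition at the one concentration tested (going by the name of the read-out) and lower numbers for less inhibition
compound 2 `C/C(=N/Nc1nc(-c2ccc(F)cc2F)cs1)c1ccco1`, 40%
compound 3 `C/C(=N/Nc1nc(-c2ccc(F)cc2F)cs1)c1cccnc1`, 40%

Compound 3 stands level with compounds 1 and 2 at the digits shown. Going by the values given here, the one step between measured compounds, no change at the digits printed from compound 2 to compound 3 (within the scatter), lies within the scatter. Compound 4 `C/C(=N/Nc1nc(-c2ccc(F)cc2F)cs1)c1ccncc1` is not yet measured; it differs from compound 3 by pyridin-4-yl in place of pyridin-3-yl on a carbon with a double bond to nitrogen. Among the compounds with values here, no measured step makes exactly this exchange, but compound 1 already carries pyridin-4-yl and gives 40%, level with compound 3, and the step of no change at the digits printed from compound 2 to compound 3 (within the scatter) shows an exchange on the carbon with a double bond to nitrogen changing nothing beyond the scatter. The step of no change at the digits printed from compound 3 to compound 4 (within the scatter) is therefore expected to stay within the scatter, in no particular direction. Compound 4 is estimated at 40%, with a range of 28% to 52%.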

Compound 4, a percentage reported as inhibition, at one concentration (the size of the read-out at that concentration, not a potency): 40%
The estimate for compound 4 equals the measured number at the digits printed; the measured number falls inside the stated range.
By their numbers in this assay, from the lowest: compounds 1, 2, 3 and 4 (each within the scatter of the next).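

In this assay, pyridin-4-yl in place of pyridin-3-yl on the carbon with a double bond to nitrogen gives no change at the digits printed from compound 3 to compound 4 (within the scatter) and so the ring nitrogen's location makes no difference beyond the scatter in this pair. Pyridin-4-yl in place of furan-2-yl gives no change at the digits printed from compound 2 to compound 4 (within the scatter) at the same place, while fluoro in place of hydrogen on an aromatic carbon, a second place of change, gives no change at the digits printed from compound 1 to compound 4 (within the scatter) in this series. No supporting data offer an explanation for these results.

Open, from the compounds shown here alone, is how an amine or a carboxylic acid would read on the carbon with a double bond to nitrogen. Also open, going by these compounds, is whether chloro or methoxy in place of fluoro would leave the read-out within the scatter.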